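The compounds below may be only part of what the source reports. "The series", "measured", "known", "first", "only" and "open" are said of these compounds alone.

Compound 1 `COc1ccc(/C=N/NC(=O)CSc2nnnn2-c2cccc3ccccc23)cc1` is the starting point. In an ADME assay on MT4 cells (Homo sapiens) for cytotoxicity, read by MTT assay (a lower number here means that less compound is tolerated, a higher number that more compound is tolerated), compound 1 gives > 298000 nM, which is a limit of the assay rather than a number (the limit of > 298000 nM in this assay, at which 1 of the 2 values shown sits). Compound 2 `COc1ccc(/C=N/NC(=O)CSc2nnnn2-c2cccc3ccccc23)c(OC)c1` carries an extra methoxy group; in this assay compound 2 gives 28300 nM. Within the data shown here, the step of an at least 10-fold lower number from compound 1 to compound 2 (1.02 log units; beyond the scatter) is the only measured step here. Compound 2 therefore holds the only number shown, since the other value is a limit.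

Compound 3 `O=C(CSc1nnnn1-c1cccc2ccccc12)N/N=C/c1cccc(O)c1` is the next compound. Its change from compound 2 is 3-hydroxyphenyl in place of 2,4-dimethoxyphenyl on a carbon with a double bond to nitrogen. Among the measured compounds shown here, the one step that bears on it, an at least 10-fold lower number from compound 1 to compound 2 (1.02 log units; beyond the scatter), went with adding a methoxy group; the change to compound 3 removes both methoxy groups and brings in a hydroxyl instead, so it runs partly against that step. A rise back toward the limit is expected, with wide uncertainty. Compound 3 is expected to give about 120000 nM, between 25000 nM and 300000 nM. The expected step is a 4.2-fold higher number from compound 2 to compound 3 (0.63 log units; beyond the scatter).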

Compound 3, half-maximal cytotoxic concentration: 169000 nM
Compound 3: middle estimate off by 1.4-fold (0.15 log units), on the low side, and the stated range covers the measured number.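

On the carbon with a double bond to nitrogen, replacing 2,4-dimethoxyphenyl with 3-hydroxyphenyl brings a 6.0-fold higher number from compound 2 to compound 3 (0.78 log units; beyond the scatter) in this assay, so the shared core alone does not set the low number of compound 2. Replacing 4-methoxyphenyl with 3-hydroxyphenyl at the same place brings an at least 1.7-fold lower number from compound 1 to compound 3 (0.24 log units; that floor lies within the scatter), so this pair does not firmly separate the two groups. The value of compound 1 is a limit and not a number, which leaves the true size of that step unknown: the limit of > 298000 nM in this assay, at which 1 of the 3 values shown sits.

The step from compound 2 to compound 3 removes two methoxy groups and adds a hydroxyl at once, so the compounds shown cannot say which part of the change matters. Going by these compounds, how an amine or a carboxylic acid on that phenyl ring would read in this assay also stays open.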